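The source may hold more compounds than are shown below. What is called first, only, known or untested is meant among the compounds shown, and "the series" means these compounds.

Values in a functional assay on DU-145 cells (Homo sapiens) for inhibition, read by trypan blue exclusion, with a stated time of 96 h (a lower number here means a stronger inhibitor of growth, a higher number a weaker inhibitor of growth), so far:
- compound 1 `Cc1ccc(S(=O)(=O)/C(=C/c2ccc(Cl)cc2)C(=O)c2ccc(Cl)cc2)cc1` gives 1000 nM
- compound 2 `Cc1ccc(CS(=O)(=O)/C(=C/c2c[nH]c3ccccc23)C(=O)c2ccc(Cl)cc2)cc1` gives 25000 nM
- compound 3 `COc1ccccc1/C=C(\C(=O)c1ccc(Cl)cc1)S(=O)(=O)Cc1ccc(C)cc1` gives 10000 nM

Compound 3 at 10000 nM holds the middle of the three numbers, with compound 2 higher and compound 1 lower, both gaps beyond the scatter. Next is compound 4 `Cc1ccc(CS(=O)(=O)/C(=C/c2ccc(Cl)cc2)C(=O)c2ccc(Cl)cc2)cc1`, which carries 4-chlorophenyl in place of 2-methoxyphenyl on a double-bonded chain carbon bound to a double-bonded chain carbon is the counted change. Going by the values given here, one measured step bears on this place: a 2.5-fold lower number from compound 2 to compound 3 (0.40 log units; beyond the scatter) is modest but beyond the scatter, so the number has moved with the group here. Among the compounds with values here, compound 1 also bears 4-chlorophenyl at this place and gives 1000 nM as the lowest number so far, but it differs from compound 4 elsewhere, so it is only weak guidance. A modest move to a lower number is therefore expected in this assay and the estimated size is a 3.3-fold lower number from compound 3 to compound 4 (0.52 log units; beyond the scatter) for this change. For compound 4 the estimated value is 3000 nM with 800 nM to 10000 nM as the expected range.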

Compound 4, concentration for 50% growth inhibition: 25000 nM
Beside the measured number, compound 4's estimate is 8.3-fold (0.92 log units) below it; measured number above the stated range.
By their numbers in this assay, from the lowest: compound 1; then compound 3; then compounds 2 and 4 (each within the scatter of the next).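

In this assay, going by these compounds alone, with 4-methylbenzyl held on the sulfonyl sulfur, the change to 4-chlorophenyl gives a 2.5-fold higher number from compound 3 to compound 4 (0.40 log units; beyond the scatter) and the change from 1H-indol-3-yl to 4-chlorophenyl gives no change at the digits printed from compound 2 to compound 4 (within the scatter) so 2-methoxyphenyl is the only one of these three groups with a lower number. The larger move comes from the other place, where 4-methylbenzyl in place of 4-methylphenyl on a sulfonyl sulfur gives a 25-fold higher number from compound 1 to compound 4 (1.40 log units; beyond the scatter) and the low number of compound 1 therefore does not carry over with 4-chlorophenyl alone. No evidence at hand accounts for either step.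

As far as these compounds go, whether 2-methoxyphenyl would also lower the number with 4-methylphenyl on the sulfonyl sulfur remains open. Also open, from the compounds shown here alone, is how a longer chain such as 2-phenylethyl on that sulfur, or a carboxylic acid on the aromatic ring at the double-bonded chain carbon, would read.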